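Working notes on the aryl swap toward compound 4

The source may hold more compounds than are shown below. What is called first, only, known or untested is meant among the compounds shown, and "the series" means these compounds.

Three members of the series have been run in a functional assay on PC-12 cells (Rattus norvegicus) for cytotoxicity, read by MTT assay, with stated times of 2 h and 24 h, tested at 10 uM; on this read-out higher numbers stand for a stronger effect at the one concentration tested and lower numbers for a weaker effect. Compound 1 `Cc1ccc(-n2nc(-c3ccc(C(F)(F)F)cc3O)nc2-c2ccccc2O)cc1` gives 102%. Compound 2 `Oc1cc(C(F)(F)F)ccc1-c1nc(-c2ccccc2O)n(-c2ccc(Br)cc2)n1` gives 100% in this assay. Compound 3 `N#Cc1ccc(-n2nc(-c3ccc(C(F)(F)F)cc3O)nc2-c2ccccc2O)cc1` gives 98.9% in this assay. Compound 2 thus sits second highest of the three numbers, with compound 3 nearest and compound 1 furthest, and both gaps within the scatter. The three steps joining them are small: a number 2 percentage points lower from compound 1 to compound 2 (within the scatter), a number 3.1 percentage points lower from compound 1 to compound 3 (within the scatter) and a number 1.1 percentage points lower from compound 2 to compound 3 (within the scatter), each within the scatter, so methyl, bromo and cyano on that aromatic carbon all leave the read-out flat.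

Compound 4 `Cc1cc(C)cc(-n2nc(-c3ccc(C(F)(F)F)cc3O)nc2-c2ccccc2O)c1` has not yet been measured. Against compound 2 the change is 3,5-dimethylphenyl in place of 4-bromophenyl on an aromatic nitrogen. Within the data shown here, no measured step exchanges a whole aryl group; the three measured steps alter only one substituent on the aromatic carbon, and each is within the scatter. They bear on the present step only in that every variation of the group on the ring nitrogen tried so far has left the number level. The step expected is therefore no change at the digits printed from compound 2 to compound 4 (within the scatter), none beyond the scatter. Compound 4 is estimated at 100%, with an expected range from 90% to 110%.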

Compound 4, a percentage reported as activity, at one concentration (the size of the read-out at that concentration, not a potency): 105%
The estimate for compound 4 lay 5 percentage points below the measured number, within the range that was stated.
By their numbers in this assay, from the lowest: compounds 3, 2, 1 and 4 (each within the scatter of the next).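

The aromatic nitrogen now admits an exchange of the whole aryl group, not only of one substituent on it: in this assay, 3,5-dimethylphenyl gives a number 5 percentage points higher from compound 2 to compound 4 (within the scatter), a number 6.1 percentage points higher from compound 3 to compound 4 (within the scatter) and a number 3 percentage points higher from compound 1 to compound 4 (within the scatter). The four compounds therefore do not separate on this read-out, whether the aryl group carries one substituent, as in 4-bromophenyl, 4-cyanophenyl and 4-methylphenyl, or the two methyl groups of 3,5-dimethylphenyl, so neither the number nor the placing of these substituents shows an effect here. Nothing at hand gives a cause for this level reading.

The compounds shown leave open whether an amine or a carboxylic acid on that aryl ring, or a longer alkyl chain in place of the aryl group on the aromatic nitrogen, would carry the number beyond the scatter. They also leave open what the 2-hydroxyphenyl group and the trifluoromethyl-bearing hydroxyphenyl group contribute, as all four compounds keep both unchanged.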